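Swapping One Attached Group for Another

The compounds below may be only part of what the source reports. "The series", "measured", "known", "first", "only" and "open" are said of these compounds alone.

In a functional assay on B16-F10 cells (Mus musculus) for cytotoxicity (on this read-out higher numbers stand for weaker inhibition and lower numbers for stronger inhibition), compound 1 `O=c1oc2ccccc2c2nc3c(ccc4cc[nH]c43)c(-c3cccnc3Cl)c12` gives 70700 nM. For the measured compounds named here, compound 2 `O=c1oc2ccccc2c2nc3c(ccc4cc[nH]c43)c(-c3ccccc3)c12` gives 70700 nM in this assay, so compound 1 stands level with compound 2, the only other measured compound. Compound 3 `O=c1oc2ccccc2c2nc3c(ccc4cc[nH]c43)c(-c3cccc(Cl)c3Cl)c12` differs from compound 1 by 2,3-dichlorophenyl in place of 2-chloropyridin-3-yl on an aromatic carbon. Going by the values given here, the single measured step, no change at the digits printed from compound 1 to compound 2 (within the scatter), also exchanged the group at this same place and moved the read-out no further than the scatter. On that basis compound 3 is expected to stay level with compound 1, with the step of no change at the digits printed from compound 1 to compound 3 (within the scatter) meaning no change beyond the scatter. Compound 3 is estimated at 70700 nM, within a range from 35000 nM to 141000 nM.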

Compound 3, half-maximal inhibitory concentration: 70700 nM
Beside the measured number, compound 3's estimate shows no gap at the digits printed; the range from low to high includes it.
By their numbers in this assay, from the lowest: compounds 1, 2 and 3 (each within the scatter of the next).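

Three different aromatic rings now sit at this aromatic carbon, and the read-out has not separated them in this assay. Exchanging the ring nitrogen and its chlorine for 2,3-dichlorophenyl gives no change at the digits printed from compound 1 to compound 3 (within the scatter), and replacing plain phenyl with the same group gives no change at the digits printed from compound 2 to compound 3 (within the scatter). No evidence is available to explain this flat result. As far as these compounds go, whether an amine or a carboxylic acid at this aromatic carbon would shift the read-out remains open. So does whether a change elsewhere on the shared core would do so.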